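The source may hold more compounds than are shown below. What is called first, only, known or untested is meant among the compounds shown, and "the series" means these compounds.

In a functional assay on HCT-116 cells (Homo sapiens) for antiproliferative activity, read by sulforhodamine B assay, with a stated time of 48 h (on this read-out lower numbers stand for stronger inhibition and higher numbers for weaker inhibition), compound 1 (`COc1cc(O)c(C(=O)/C=C/c2ccc(F)cc2)c(OC)c1`) gives 4400 nM and compound 2 (`COc1ccc(/C=C/C(=O)c2c(OC)cc(OC)cc2OCC=C(C)C)cc1`) gives 7600 nM. Among the compounds with values here, these two values lie within the usual scatter of each other, so compound 2 cannot be told apart from the only other compound measured so far. Compound 3 (`COc1cc(OC)c(C(=O)/C=C/c2ccc(F)cc2)c(OCC=C(C)C)c1`) differs from compound 2 in one place: fluoro in place of methoxy on an aromatic carbon. In words, a fluoro stands in place of a methoxy on an aromatic carbon, which turns 4-methoxyphenyl into 4-fluorophenyl. Within the data shown here, no measured pair of compounds shows what this exchange does, so the data offer no direct guide to its direction. The expectation in this assay is therefore no shift beyond the scatter, and the estimated 1.3-fold lower number from compound 2 to compound 3 (0.10 log units; within the scatter) is expected to stay small. For compound 3 the expected value is 6000 nM, with an estimated range of 2500 nM to 15000 nM.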

Compound 3, half-maximal inhibitory concentration: 3200 nM
Compound 3: middle estimate off by 1.9-fold (0.27 log units), on the high side, and the stated range covers the measured number.
By their numbers in this assay, from the lowest: compounds 3, 1 and 2 (each within the scatter of the next, the first and the last beyond it).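

The exchange of 4-methoxyphenyl for 4-fluorophenyl now has a direct reading in this assay (a 2.4-fold lower number from compound 2 to compound 3 (0.38 log units; beyond the scatter)): at this place on the ring, para to a large group, fluoro in place of methoxy gives a modest step beyond the scatter. The other exchange, 3-methylbut-2-en-1-yl in place of hydrogen on an oxygen on an aromatic ring, stays within the scatter (a 1.4-fold lower number from compound 1 to compound 3 (0.14 log units; within the scatter)), so this single pair shows no clear effect of adding that chain. Nothing measured here explains the step from methoxy to fluoro.

A single exchange cannot show whether other groups at this place, such as chloro, an amine or a carboxylic acid, would give lower or higher numbers. It also leaves open whether the fluoro-for-methoxy step would be the same size with hydrogen or a longer chain on that oxygen.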